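Cyclobutyl to Cyclopentyl Ester: What Compound 4 Might Show

The source may report more compounds than this note shows. Statements on the series, on what has been measured and on what is new or still open speak of the compounds shown alone.

Three compounds have been measured in an assay on membranes from HEK293 cells for displacement of a labelled ligand from adenosine receptor A2b (Homo sapiens), read by scintillation counting, with a stated time of 30 min; a lower number here means a stronger inhibitor, a higher number a weaker inhibitor:

compound 1, `CC1=C(C(=O)C2CC2)C(c2ccco2)NC(=O)N1`: 1060 nM
compound 2, `CCCC(=O)C1=C(C)NC(=O)NC1c1ccco1`: 807 nM
compound 3, `CC1=C(C(=O)OC2CCC2)C(c2ccco2)NC(=O)N1`: 95.1 nM

Compound 3 gives the lowest number of the three. The two steps that lead to it are of clear size: an 11-fold lower number from compound 1 to compound 3 (1.05 log units; beyond the scatter) and an 8.5-fold lower number from compound 2 to compound 3 (0.93 log units; beyond the scatter). The step between the two ketones, a 1.3-fold lower number from compound 1 to compound 2 (0.12 log units; within the scatter), is within the scatter.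

Compound 4, `CC1=C(C(=O)OC2CCCC2)C(c2ccco2)NC(=O)N1`, differs from compound 3 in one place: cyclopentyl in place of cyclobutyl on an oxygen next to a carbonyl group. Among the measured compounds shown here, no measured step changes the ring size of this group; the two steps that reach compound 3 concern the exchange of a ketone for an ester, and the ester is kept in compound 4. The measured data therefore give no direct guide to the size or direction of this step, and the closest comparison, compound 1 against compound 2, shows that a small change in a carbon group can leave the number within the scatter.

The step from compound 3 to compound 4 is thus expected to be small: a 1.1-fold lower number from compound 3 to compound 4 (0.05 log units; within the scatter). Compound 4 is estimated at 85 nM, in a range of 30 nM to 250 nM.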

Compound 4, inhibition constant: 577 nM
Estimate against measurement, compound 4: 6.8-fold (0.83 log units) below; measured number above the stated range.
By their numbers in this assay, from the lowest: compound 3; then compounds 4, 2 and 1 (each within the scatter of the next).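

In this assay, this position proves sensitive to ring size. Cyclopentyl in place of cyclobutyl on an oxygen next to a carbonyl group gives a 6.1-fold higher number from compound 3 to compound 4 (0.78 log units; beyond the scatter), so keeping the ester does not by itself preserve the low number of compound 3. The ketone comparisons change as well: a 1.4-fold lower number from compound 2 to compound 4 (0.15 log units; within the scatter) and a 1.8-fold lower number from compound 1 to compound 4 (0.26 log units; within the scatter) both lie within the scatter, which leaves compound 3 as the only one of the four whose steps to all the others are beyond it, and shows that the ester of compound 4 is not separated from either ketone. The data shown offer no explanation for the difference between the two rings.

The compounds shown leave open how other groups on this oxygen would read in this assay, such as cyclopropyl, isopropyl, cyclohexyl or a longer chain such as butyl, and so whether cyclobutyl stands alone or is one of several groups with low numbers. They also leave open whether the change from cyclobutyl to cyclopentyl gives a step of similar size when another part of the shared core is altered.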